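A few compounds are considered here, and "the series" means these few. Any claim that something is new, unique, unknown or untested is made for them only; others in the source may bear on it.

Series notes. The shared core is that of compound 1 `c1ccc(C2=NN(C3=NC(c4ccccc4)CS3)C(c3cccc4ccccc34)C2)cc1`, which in a functional assay on HeLa cells (Homo sapiens) for inhibition, read by CCK-8 assay, with a stated time of 48 h (a lower number here means a stronger inhibitor, a higher number a weaker inhibitor), gives 5320 nM. Compound 2 `Cc1ccc(C2=NN(C3=NC(c4ccccc4)CS3)C(c3cccc4ccccc34)C2)cc1C` carries 3,4-dimethylphenyl on the carbon with a double bond to nitrogen in place of the phenyl of compound 1, and in this assay compound 2 gives 1720 nM. For the measured compounds named here, only these two numbers are known; on them compound 2 stands lowest, its one neighbour being compound 1, and the step of a 3.1-fold lower number from compound 1 to compound 2 (0.49 log units; beyond the scatter) is the only measured step in the set.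

Compound 3 `Clc1ccc(C2=NN(C3=NC(c4ccccc4)CS3)C(c3cccc4ccccc34)C2)cc1` is not yet measured. Relative to compound 2 the change is 4-chlorophenyl in place of 3,4-dimethylphenyl on a carbon with a double bond to nitrogen. Going by the values given here, no measured step swaps one substituted phenyl for another at this position; the single step that bears on it, from compound 1 to compound 2, shows that a substituent on this ring can move the number by a modest amount, and 4-chlorophenyl has not been tried here. Compound 3 is expected to land between the numbers of compound 1 and compound 2, nearer the latter, the estimated step being a 1.5-fold higher number from compound 2 to compound 3 (0.16 log units; within the scatter), within the scatter. The estimate for compound 3 in this assay is 2500 nM, with a range from 900 nM to 7000 nM.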

Compound 3, half-maximal inhibitory concentration: 9940 nM
For compound 3 the middle estimate is 4.0-fold (0.60 log units) below the measured one, outside the stated range (above it).
By their numbers in this assay, from the lowest: compound 2; then compounds 1 and 3 (each within the scatter of the next).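

In this assay, 4-chlorophenyl in place of 3,4-dimethylphenyl on the carbon with a double bond to nitrogen gives a 5.8-fold higher number from compound 2 to compound 3 (0.76 log units; beyond the scatter), the largest step yet seen at this position, which shows that a substituent on this ring does not in itself bring the number down. Chloro in place of hydrogen on an aromatic carbon gives a 1.9-fold higher number from compound 1 to compound 3 (0.27 log units; within the scatter), so compound 3 cannot be told apart from compound 1, and of the two substituted rings only the 3,4-dimethylphenyl of compound 2 stands apart from the unsubstituted phenyl. No data at hand bear on what separates the two substituted rings.

The compounds shown leave open whether a single methyl, as in 4-methylphenyl, is enough to reach the number of compound 2, and whether 3,4-dichlorophenyl would sit with compound 2 or with compound 3. Also open, on these data alone, is what a ring carrying an amine or a carboxylic acid would give at this position, and what a pyridine in place of the naphthalen-1-yl group would give.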